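This account rests on a few compounds, and the source may have more. Where it says the series, first, only, none or still open, it means among the compounds named here.

Measured compounds:
- compound 1 `CC(C)/N=c1\c(O)c(O)\c1=N/c1ccc(C#N)cc1`: 13700 nM
- compound 2 `CCC(C)(C)/N=c1\c(O)c(O)\c1=N/c1ccc(C#N)cc1`: > 30000 nM
- compound 3 `Cc1cc(C#N)ccc1/N=c1\c(O)c(O)\c1=N/[C@H](C)C(C)(C)C`: 1080 nM

In a functional assay for inhibition, with Rattus norvegicus as the target (on this read-out lower numbers stand for stronger inhibition and higher numbers for weaker inhibition), compound 1 gives 13700 nM. For compound 2 the result is a limit of the assay, > 30000 nM, and not a number. The change between them is ethyl in place of hydrogen on a saturated chain carbon bound to a double-bonded nitrogen and two saturated chain carbons. The step it made is an at least 2.1-fold higher number from compound 1 to compound 2 (0.34 log units; beyond the scatter), an outcome that rests on (the limit of > 30000 nM in this assay, at which 1 of the 3 values shown sits).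

Compound 3 gives 1080 nM, the lowest number among the two compounds with a number; compound 1 stands nearest to it, a clear gap higher. The difference between the core of compound 1 and the core of compound 3 is not broken down here.

Compound 4 `CCCc1cc(C#N)ccc1/N=c1\c(O)c(O)\c1=N/[C@H](C)C(C)(C)C` is not yet measured. Relative to compound 3 the change is ethyl in place of hydrogen on a saturated chain carbon bound to an aromatic carbon. Among the measured compounds shown here, this is the same kind of change as the one from compound 1 to compound 2, but the place differs: there the ethyl enters on a saturated chain carbon bound to a double-bonded nitrogen and two saturated chain carbons, here on a saturated chain carbon bound to an aromatic carbon. For the measured compounds named here, the only measured precedent, an at least 2.1-fold higher number from compound 1 to compound 2 (0.34 log units; beyond the scatter), points to a higher number, and an ethyl entering at the new place is expected to give a step of a 2.0-fold higher number from compound 3 to compound 4 (0.31 log units; beyond the scatter). For compound 4 the expected value in this assay is 2200 nM, with a plausible range from 900 nM to 6000 nM.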

Compound 4, half-maximal inhibitory concentration: 23100 nM
Compound 4: the middle estimate sits 11-fold (1.02 log units) below what was measured, outside the stated range (above it).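

In this assay, ethyl in place of hydrogen on a saturated chain carbon bound to an aromatic carbon, which turns methyl into propyl, gives a 21-fold higher number from compound 3 to compound 4 (1.33 log units; beyond the scatter), so weaker inhibition follows the change in both pairs of this series, though the size of the change cannot be said to carry over from one core to the other: the same change on two cores in this assay, an at least 2.1-fold higher number (0.34 log units; beyond the scatter) from compound 1 to compound 2 and a 21-fold higher number (1.33 log units; beyond the scatter) from compound 3 to compound 4; the limit leaves it open whether they differ. Compound 2 gives a limit of the assay and not a number, so the earlier step is only a bound and sets no size for the change: the limit of > 30000 nM in this assay, at which 1 of the 4 values shown sits. The ethyl also enters at a different place in each pair, so these two pairs cannot separate an effect of the core from an effect of the place, and they make no general rule for the series.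

Open, on these data alone, is how the read-out runs between and beyond the methyl of compound 3 and the propyl of compound 4, for instance with an ethyl or a butyl chain in that place. Also open, as far as these compounds go, is whether a group of another kind there, such as a methoxy group or an amine, would follow the same direction.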